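The source may report more compounds than this note shows. Statements on the series, on what has been measured and on what is new or still open speak of the compounds shown alone.

Notes on the amide series sharing one core. Compound 1 `CN1[C@@H]2c3[nH]c4ccccc4c3C[C@H]1[C@H](C#N)N1[C@@H](CNC(=O)c3ccc(Cl)cc3)c3[nH]c4ccccc4c3C[C@@H]21` gives 610 nM in a functional assay on MCF7 cells (Homo sapiens) for cytotoxicity, read by MTT assay, with a stated time of 72 h; a lower number here means a stronger inhibitor, a higher number a weaker inhibitor. Compound 2 `CN1[C@@H]2c3[nH]c4ccccc4c3C[C@H]1[C@H](C#N)N1[C@@H](CNC(=O)c3ccc4ccccc4n3)c3[nH]c4ccccc4c3C[C@@H]21` gives 150 nM in this assay, and the change from compound 1 is a 4.1-fold lower number from compound 1 to compound 2 (0.61 log units; beyond the scatter). Compound 3 `CN1[C@@H]2c3[nH]c4ccccc4c3C[C@H]1[C@H](C#N)N1[C@@H](CNC(=O)c3cc4ccccc4o3)c3[nH]c4ccccc4c3C[C@@H]21` gives 320 nM in this assay; the change from compound 1 is a 1.9-fold lower number from compound 1 to compound 3 (0.28 log units; within the scatter), and from compound 2 to compound 3 it is a 2.1-fold higher number from compound 2 to compound 3 (0.33 log units; beyond the scatter). Compound 3 thus stands second highest of the three numbers, near compound 1 and apart from compound 2.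

Compound 4 `COc1ccc(/C=C/C(=O)NC[C@H]2c3[nH]c4ccccc4c3C[C@H]3[C@H]4c5[nH]c6ccccc6c5C[C@@H]([C@H](C#N)N23)N4C)cc1` is not yet measured. It differs from compound 3 by 2-(4-methoxyphenyl)ethenyl in place of 1-benzofuran-2-yl on a carbonyl carbon. The two measured steps at the same carbonyl carbon were the modest one from compound 1 to compound 2 and the small one from compound 1 to compound 3; both swapped one aryl group for another, and neither introduced a double bond outside aromatic rings, so they bear on the step to compound 4 only loosely. Among the compounds with values here, no measured step tests the new group. In this assay a step of about a 1.3-fold higher number from compound 3 to compound 4 (0.10 log units; within the scatter) is therefore expected, of uncertain direction, most likely within the scatter of the three numbers seen. Compound 4 is estimated at 400 nM in this assay, in the range 150 nM to 1200 nM.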

Compound 4, half-maximal inhibitory concentration: 4220 nM
Beside the measured number, compound 4's estimate is 11-fold (1.02 log units) below it, outside the stated range (above it).
By their numbers in this assay, from the lowest: compound 2; then compounds 3 and 1 (each within the scatter of the next); then compound 4.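

At the carbonyl carbon, this assay now shows that the group there can move the number well beyond what the aryl-for-aryl swaps did. With 2-(4-methoxyphenyl)ethenyl in place, the step is large from 1-benzofuran-2-yl (a 13-fold higher number from compound 3 to compound 4 (1.12 log units; beyond the scatter)) and from quinolin-2-yl (a 28-fold higher number from compound 2 to compound 4 (1.45 log units; beyond the scatter)), and modest from 4-chlorophenyl (a 6.9-fold higher number from compound 1 to compound 4 (0.84 log units; beyond the scatter)), so compound 4 is the weakest of the four. Nothing available accounts for this loss.

The compounds shown do not separate the contribution of the double bond from that of the methoxy group, since both enter in the one change. As far as these compounds go, a 2-(4-methoxyphenyl)ethyl chain or a 4-methoxyphenyl group on the same carbonyl carbon would divide the two, and whether an amine on the aryl ring is tolerated here remains open.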